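Moving atoms within the side chain of compound 2

The compounds below may be only part of what the source reports. "The series", "measured", "known", "first", "only" and "open" are said of these compounds alone.

Three compounds have been measured in a functional assay on the whole organism (stomach) with Rattus norvegicus as the target; a higher number here means that more compound is needed for the effect, a lower number that less compound is needed:
compound 1 `CC/N=C(/NC#N)NCCCCn1nc(-c2ccccc2)ccc1=O` gives 92 mg/kg;
compound 2 `C/N=C(\NC#N)NCCCCn1nc(-c2ccccc2)ccc1=O` gives 32.4 mg/kg;
compound 3 `C/N=C(/NC#N)N(C)CCCCn1nc(-c2ccccc2)ccc1=O` gives only a limit of the assay.
For compound 3 that limit is > 100 mg/kg.

Compound 2 gives the lowest of the two real numbers; the step of a 2.8-fold lower number from compound 1 to compound 2 (0.45 log units; beyond the scatter) lies beyond the scatter. Compound 4 `CN(C)/C(=N/CCCn1nc(-c2ccccc2)ccc1=O)NC#N` keeps every atom of compound 2 but joins them differently: a group of 8 heavy atoms (4 carbon, 4 nitrogen; no ring) in place of a group of 8 heavy atoms (4 carbon, 4 nitrogen; no ring), on a saturated chain carbon, three bonds along the chain from an aromatic nitrogen. The step that bears on this is an at least 3.0-fold higher number from compound 2 to compound 3 (0.48 log units; beyond the scatter), where a change on the same chain took the reading to the assay limit (the limit of > 100 mg/kg in this assay, at which 1 of the 3 values shown sits). The expected step is therefore upward, a 2.8-fold higher number from compound 2 to compound 4 (0.44 log units; beyond the scatter). For compound 4 the estimate is 90 mg/kg, ranging from 35 mg/kg to 250 mg/kg.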

Compound 4, dose for half-maximal effect: 53 mg/kg
Compound 4: the middle estimate sits 1.7-fold (0.23 log units) above what was measured, within the range that was stated.
By their numbers in this assay, from the lowest: compounds 2, 4 and 1 (each within the scatter of the next, the first and the last beyond it). At a limit, above all of these: compound 3.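

In this assay, the rearrangement at this saturated chain carbon, three bonds along the chain from an aromatic nitrogen, gives a 1.6-fold higher number from compound 2 to compound 4 (0.21 log units; within the scatter). The same atoms can therefore be joined differently here without a reading that can be told apart from that of compound 2. This holds even though the entering group has 1 hydrogen-bond donor where the leaving group has 2.

Still open, going by these compounds, is which part of the rearrangement matters, the chain or the dimethylamino end. A longer chain carrying that end, or a piperidine ring in its place, could help separate the two.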